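The source may hold more compounds than are shown below. What is called first, only, known or untested is meant among the compounds shown, and "the series" means these compounds.

Among the measured compounds shown here, only two compounds have numbers so far in a functional assay on HL-60 cells (Homo sapiens) for inhibition, read by MTT assay, with a stated time of 72 h, tested at 50 uM; a lower number here means less inhibition of growth, a higher number more inhibition of growth at the concentration tested. Compound 1 (`C=CCc1ccc(OCc2cn(-c3cccc([N+](=O)[O-])c3)nn2)c(O)c1`) gives 65.5%. Compound 2 (`C=CCc1cc(O)c(O)c(CN2CCC(C)CC2)c1`) gives 91.8%, the higher of the two numbers, and the gap to compound 1 lies beyond the scatter. Compound 3 (`C=CCc1cc(O)c(O)c(CN2CCC(CCO)CC2)c1`) is still unmeasured. Its difference from compound 2 is hydroxymethyl in place of hydrogen on a saturated chain carbon bound to a saturated ring carbon, which, cut one bond further out, reads methyl to 2-hydroxyethyl. For the measured compounds named here, no measured pair shows a change of this kind, so the data offer no direct precedent. With compound 2 at 91.8%, little room remains upward. The expected step of a number 6.8 percentage points lower from compound 2 to compound 3 (within the scatter) is a small fall in this assay, most likely not beyond the scatter. For compound 3 the estimated value is 85%, with an expected range of 68% to 97%.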

Compound 3, percent growth inhibition at one concentration: 52.1%
The estimate for compound 3 lay 32.9 percentage points above the measured number; measured number below the stated range.
By their numbers in this assay, from the lowest: compound 3; then compound 1; then compound 2.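

This position does not tolerate every change: in this assay, hydroxymethyl in place of hydrogen on a saturated chain carbon bound to a saturated ring carbon gives a number 39.7 percentage points lower from compound 2 to compound 3 (beyond the scatter). Read one bond further out as methyl to 2-hydroxyethyl, this is the first single change in the series with a measured effect, and the high growth inhibition of compound 2 does not carry over to compound 3. Nothing at hand accounts for a step of this size.

The pair leaves open whether the fall follows the added chain length or the hydroxyl group, as both enter together in compound 3. Ethyl, 2-methoxyethyl or 2-aminoethyl in the same place would tell these apart, and a longer chain ending in hydroxyl would show whether the fall continues.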